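The source may report more compounds than this note shows. Statements on the series, on what has been measured and on what is new or still open speak of the compounds shown alone.

In a functional assay on HCT-116 cells (Homo sapiens) for antiproliferative activity, read by sulforhodamine B assay, with a stated time of 72 h (a higher number here means a weaker inhibitor, a lower number a stronger inhibitor), compound 1 (`Cn1ncc(Cl)c1-c1cc(C(=O)N[C@@H]2CN[C@H](CCNS(C)(=O)=O)C[C@H]2c2ccc(F)c(F)c2)oc1Cl`) gives 920 nM and compound 2 (`C=CC[C@@H]1C[C@@H](c2ccc(Cl)c(Cl)c2)[C@H](NC(=O)c2cc(-c3c(Cl)cnn3C)c(Cl)o2)CN1`) gives 780 nM. Among the compounds with values here, these two numbers lie within the scatter of each other, so compound 1 stands level with the only other measured compound. Compound 3 (`CC(=O)OCC[C@@H]1C[C@@H](c2ccc(F)c(F)c2)[C@H](NC(=O)c2cc(-c3c(Cl)cnn3C)c(Cl)o2)CN1`) carries acetoxy in place of methanesulfonamido on a saturated chain carbon, two bonds along the chain from a saturated ring carbon. Within the data shown here, no measured pair shows this change, so no shift beyond the scatter is expected in this assay. The estimate for compound 3 is 800 nM, with an expected range of 300 nM to 2000 nM.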

Compound 3, half-maximal inhibitory concentration: 690 nM
Estimate against measurement, compound 3: 1.2-fold (0.06 log units) above; the range from low to high includes it.
By their numbers in this assay, from the lowest: compounds 3, 2 and 1 (each within the scatter of the next).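

In this assay the exchange of methanesulfonamido for acetoxy on a saturated chain carbon, two bonds along the chain from a saturated ring carbon, gives a 1.3-fold lower number from compound 1 to compound 3 (0.12 log units; within the scatter) and so shifts nothing beyond the scatter. The position therefore reads the same here with the hydrogen-bond donor of methanesulfonamido absent from acetoxy. Nothing available explains why these two groups read alike. The compounds shown leave open whether an amine or a carboxylic acid at the end of this chain, or a longer chain, would read differently.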